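The source may hold more compounds than are shown below. What is called first, only, known or untested is meant among the compounds shown, and "the series" means these compounds.

Three compounds sharing one core were tested in an assay on isolated protein for inhibition of Ca2+/calmodulin-dependent protein kinase II (CaM kinase II) (Rattus norvegicus), tested at 30 uM; on this read-out higher numbers stand for more inhibition at the one concentration tested (going by the name of the read-out) and lower numbers for less inhibition. Compound 1, `Fc1ccc(Sc2ncnc3[nH]cnc23)cc1`, gives 0% in this assay. Compound 2, `Cn1cnc2c(Sc3ccc(F)cc3)ncnc21`, gives 5% in this assay. Compound 3, `c1ccc(Cn2cnc3c(Sc4ccccc4)ncnc32)cc1`, gives 3% in this assay. For the measured compounds named here, the only step measured between two compounds that differ in one place is a number 5 percentage points higher from compound 1 to compound 2 (within the scatter), methyl in place of hydrogen on an aromatic nitrogen, and it stays inside the scatter. Compound 3 sits among the three numbers with its nearest neighbour compound 2 and its furthest neighbour compound 1, and both of those gaps lie within the scatter, so no ordering among the three can be claimed.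

Compound 4, `Fc1ccc(Sc2ncnc3c2ncn3Cc2ccccc2)cc1`, differs from compound 3 by fluoro in place of hydrogen on an aromatic carbon. Going by the values given here, no measured step in this assay covers fluoro in place of hydrogen on an aromatic carbon; compound 1 and compound 3 carry that difference but also differ elsewhere, so only their two values, close together, can be noted. Among the compounds with values here, the one step that is known, a number 5 percentage points higher from compound 1 to compound 2 (within the scatter), is small. A step within the scatter, no change at the digits printed from compound 3 to compound 4 (within the scatter), is therefore expected. Compound 4 is estimated at 3% in this assay, with a range from -5% to 12%.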

Compound 4, a percentage reported as inhibition, at one concentration (the size of the read-out at that concentration, not a potency): 0%
Estimate against measurement, compound 4: 3 percentage points above, within the range that was stated.
By their numbers in this assay, from the lowest: compounds 1, 4, 3 and 2 (each within the scatter of the next).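

In this assay fluoro in place of hydrogen on an aromatic carbon, para to a large group, now has a measured step of its own: a number 3 percentage points lower from compound 3 to compound 4 (within the scatter) shows that going from phenylsulfanyl to (4-fluorophenyl)sulfanyl leaves the read-out within the scatter when benzyl sits on the aromatic nitrogen. With the fluoro group held constant, the group on that nitrogen can also be read in two further steps, a number 5 percentage points lower from compound 2 to compound 4 (within the scatter) for phenyl in place of hydrogen on a saturated chain carbon bound to an aromatic nitrogen and no change at the digits printed from compound 1 to compound 4 (within the scatter) for a swap of the hydrogen on that nitrogen for benzyl, so hydrogen, methyl and benzyl there cannot be told apart in these compounds. No evidence is available that bears on this result.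

All four compounds lie within the scatter of one another, so these compounds leave open whether any change to this series can move the read-out beyond the scatter. That question remains for other groups on the phenyl ring, such as a methoxy group or a carboxylic acid, and for an amine or a longer chain on the aromatic nitrogen.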